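This account rests on a few compounds, and the source may have more. Where it says the series, first, only, none or still open, it means among the compounds named here.

Measured compounds:
- compound 1 `COc1ccc2[nH]c(C(=O)N3CC(=O)N(Cc4ccccc4)[C@@H](COc4ccccc4)C3)cc2c1`: 12200 nM
- compound 2 `COc1cccc(CN2C(=O)CN(C(=O)c3cc4cc(OC)ccc4[nH]3)C[C@@H]2CCc2ccccc2)c1`: 5100 nM
- compound 3 `COc1cccc(CN2C(=O)CN(C(=O)c3cc4cc(OC)ccc4[nH]3)C[C@@H]2c2ccccc2)c1`: 13600 nM

These three share one core and were measured in a physicochemical assay for solubility, read by spectrophotometry, in phosphate buffer, with a stated time of 2 h, at pH 7.4; a higher number here means a more soluble compound, a lower number a less soluble compound. Compound 1 stands second highest of the three numbers; compound 3 lies within the scatter of it, while compound 2 sits lower by a gap beyond the scatter. Within the data shown here, the only single-place step among the measured compounds is a 2.7-fold higher number from compound 2 to compound 3 (0.43 log units; beyond the scatter), a change on a saturated ring carbon that does not involve the group altered here.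

Compound 4 `COc1ccc2[nH]c(C(=O)N3CC(=O)N(Cc4ccccc4)[C@@H](N4[C@H](C)CCC[C@@H]4C)C3)cc2c1` is not yet measured. It differs from compound 1 in one place: 2,6-dimethylpiperidin-1-yl in place of phenoxymethyl on a saturated ring carbon. No measured step in this assay swaps a phenoxymethyl for a 2,6-dimethylpiperidin-1-yl, so nothing shown here points to a direction. The leaving and entering groups carry the same count of heavy atoms and of hydrogen-bond acceptors, so the expected step of a 1.0-fold lower number from compound 1 to compound 4 (0.01 log units; within the scatter) is small, not clearly beyond the scatter. Compound 4 is therefore estimated at 12000 nM, with a range from 4000 nM to 36000 nM.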

Compound 4, solubility: 100000 nM
The estimate for compound 4 lay 8.3-fold (0.92 log units) below the measured number; measured number outside the range, above it.
By their numbers in this assay, from the lowest: compound 2; then compounds 1 and 3 (each within the scatter of the next); then compound 4.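

In this assay the swap on this saturated ring carbon gives an 8.2-fold higher number from compound 1 to compound 4 (0.91 log units; beyond the scatter) even though phenoxymethyl and 2,6-dimethylpiperidin-1-yl have the same counts of heavy atoms and hydrogen-bond acceptors. Matching those counts therefore did not keep the number in place, and the group on this carbon can move it beyond the scatter. Among these compounds, the only earlier step, phenyl in place of phenethyl, involved neither of these groups, and no measurement of any property of the two groups is available to account for the new step.

Going by these compounds, it remains open whether a plain piperidin-1-yl without the two methyl groups, a morpholine or an open-chain diethylamino group on this carbon would give a similarly high number. On these data alone, the effect of a different arrangement of the two defined stereocentres in the 2,6-dimethylpiperidin-1-yl group also remains open.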